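Replacing nitro with methoxycarbonyl: notes on the series

A few compounds are considered here, and "the series" means these few. Any claim that something is new, unique, unknown or untested is made for them only; others in the source may bear on it.

In a functional assay for inhibition, with Homo sapiens as the target (on this read-out higher numbers stand for weaker inhibition and lower numbers for stronger inhibition), compound 1 `COc1ccccc1C(=O)/C=C/c1ccccc1` gives 2230 nM, compound 2 `CCOc1ccccc1C(=O)/C=C/c1ccccc1` gives 609 nM and compound 3 `O=C(/C=C/c1ccccc1)c1ccccc1[N+](=O)[O-]` gives 1520 nM. Compound 3 cannot be separated from compound 1, as the numbers show a 1.5-fold lower number from compound 1 to compound 3 (0.17 log units; within the scatter). It does stand apart from compound 2, with a 2.5-fold higher number from compound 2 to compound 3 (0.40 log units; beyond the scatter).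

The next structure is compound 4 `COC(=O)c1ccccc1C(=O)/C=C/c1ccccc1`, which carries methoxycarbonyl in place of nitro on an aromatic carbon, ortho to a large group: methoxycarbonyl in place of nitro on an aromatic carbon. Within the data shown here, no measured step involves methoxycarbonyl, so the evidence is indirect. The nearest guide is the set of changes among the three measured compounds. The swap of nitro for methoxy gave a 1.5-fold lower number from compound 1 to compound 3 (0.17 log units; within the scatter), and the swap of nitro for ethoxy gave a 2.5-fold higher number from compound 2 to compound 3 (0.40 log units; beyond the scatter). The change from methoxy to ethoxy gave a 3.7-fold lower number from compound 1 to compound 2 (0.56 log units; beyond the scatter). Two of these steps are modest and one lies within the scatter, so none points to a large move, and none indicates a direction for this new group.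

The expected outcome is no step beyond the scatter, with an estimated 1.0-fold lower number from compound 3 to compound 4 (0.01 log units; within the scatter). For compound 4 the estimated value is 1500 nM, with an expected range of 500 nM to 4500 nM.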

Compound 4, half-maximal inhibitory concentration: 1950 nM
Estimate against measurement, compound 4: 1.3-fold (0.11 log units) below; the measured number falls inside the stated range.
By their numbers in this assay, from the lowest: compound 2; then compounds 3, 4 and 1 (each within the scatter of the next).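

In this assay, methoxycarbonyl on this aromatic carbon, ortho to a large group, cannot be told from nitro (a 1.3-fold higher number from compound 3 to compound 4 (0.11 log units; within the scatter)) or from methoxy (a 1.1-fold lower number from compound 1 to compound 4 (0.06 log units; within the scatter)), so three different groups at this place now fall within the scatter of one another. Compound 2 with its ethoxy group remains the only one that stands apart, and the new compound widens that picture with a clear gap (a 3.2-fold higher number from compound 2 to compound 4 (0.51 log units; beyond the scatter)); among these four compounds, the lowest number belongs to ethoxy alone, and a swap of nitro for methoxycarbonyl, with its one further heavy atom, moves nothing beyond the scatter. Nothing available explains why ethoxy separates from the other three groups.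

Open, from the compounds shown here alone, is whether the gain from methoxy to ethoxy carries over to the ester, as ethoxycarbonyl would show, and whether a longer chain such as propoxy takes the number further down or back up. Also open is how a carboxylic acid or an amine at this aromatic carbon would compare with the groups shown here.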